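The source may hold more compounds than are shown below. What is called first, only, known or untested is meant among the compounds shown, and "the series" means these compounds.

Going by the values given here, compound 2 `Cc1cc(C)c(Oc2ccc(N)c(Nc3ccc(C#N)cc3)c2)c(C)c1` gives 51000 nM in an ADME assay on H9 cells (Homo sapiens) for cytotoxicity, read by XTT assay, with a stated time of 6 days (a higher number here means that more compound is tolerated, a lower number that less compound is tolerated), the higher of the two plain numbers measured so far. Compound 1 `Cc1cc(C)c(Oc2cc(Nc3ccc(C#N)cc3)c(N)cc2[N+](=O)[O-])c(C)c1` gives 32200 nM in this assay, and the step of a 1.6-fold higher number from compound 1 to compound 2 (0.20 log units; within the scatter) lies within the scatter. Compound 3 `Cc1cc(Br)cc(C)c1Oc1cc(Nc2ccc(C#N)cc2)c([N+](=O)[O-])cc1[N+](=O)[O-]` reaches only a limit in this assay, > 51700 nM, a case of the limit of > 51700 nM in this assay, at which 1 of the 3 values shown sits.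

Compound 4 `Cc1cc(Br)cc(C)c1Oc1ccc(N)c(Nc2ccc(C#N)cc2)c1` differs from compound 2 by bromo in place of methyl on an aromatic carbon. Among the compounds with values here, no measured step tests this exchange: the single step seen, nitro to hydrogen, changed nothing beyond the scatter, and compound 3, which carries bromo, differs from the others in more than one place. The expectation is therefore no step beyond the scatter, with compound 4 estimated at 50000 nM (from 25000 nM to 100000 nM), meaning a 1.0-fold lower number from compound 2 to compound 4 (0.01 log units; within the scatter).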

Compound 4, half-maximal cytotoxic concentration: 44600 nM
Compound 4: the middle estimate sits 1.1-fold (0.05 log units) above what was measured; the range from low to high includes it.
By their numbers in this assay, from the lowest: compounds 1, 4 and 2 (each within the scatter of the next). At a limit, above all of these: compound 3.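

Going by these compounds alone, compound 4 gives the first direct reading of this position, on an aromatic carbon para to a large group: bromo in place of methyl gives a 1.1-fold lower number from compound 2 to compound 4 (0.06 log units; within the scatter), so the two groups cannot be told apart here. Compound 3 also carries bromo, but it differs in more than one place and gives only a limit: the limit of > 51700 nM in this assay, at which 1 of the 4 values shown sits.

Only methyl and bromo have been compared at this position. From the compounds shown here alone, whether a larger group, such as a methoxy group, or an amine there would move the number beyond the scatter remains open.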